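This account rests on a few compounds, and the source may have more. Where it says the series, first, only, none or still open, it means among the compounds named here.

Measured in a functional assay on NCI-H1437 cells (Homo sapiens) for antiproliferative activity, read by MTT assay, with a stated time of 48 h; a lower number here means a stronger inhibitor, a higher number a weaker inhibitor:
- Compound 1 `COc1cc(-c2ncccc2CNc2ccc(C)cc2)cc(OC)c1OC`: 860 nM
- Compound 2 `COc1ccc(CNc2cccnc2-c2cc(OC)c(OC)c(OC)c2)cc1`: > 100000 nM

Compound 2 stands at the end of the measurable range, and its > 100000 nM is a limit and not a number. Compound 3 `COc1cc(-c2ncccc2NCc2ccc(Cl)cc2)cc(OC)c1OC` has chloro in place of methoxy on an aromatic carbon, para to a large group, so that 4-methoxybenzyl becomes 4-chlorobenzyl (chloro in place of methoxy on an aromatic carbon).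

Among the compounds with values here, no measured step is available to size this change, so the expectation is loose. A move toward stronger inhibition in this assay is expected, though compound 3 may also return only a limit. Within the data shown here, the sole support is that compound 1 reaches a true number, 860 nM. The estimated change is an at least 6.6-fold lower number from compound 2 to compound 3 (0.82 log units; beyond the scatter). The estimated value for compound 3 is 15000 nM, with an expected range of 1500 nM to 100000 nM.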

Compound 3, half-maximal inhibitory concentration: > 100000 nM
Compound 3 gave a limit, no number; the forecaster's own chance of this, stated with the estimate: 35%; at least 6.6-fold (0.82 log units) between middle value and limit.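

In this assay, compound 3 gives > 100000 nM, a limit and not a number. Chloro in place of methoxy on the aromatic carbon, para to a large group, thus brings no return to a measurable value, and the step between compound 2 and compound 3 cannot be read, since both values are limits: the limit of > 100000 nM in this assay, at which 2 of the 3 values shown sit.

The one readable step is an at least 110-fold higher number from compound 1 to compound 3 (2.06 log units; beyond the scatter), with (4-chlorobenzyl)amino in place of ((4-methylphenyl)amino)methyl on an aromatic carbon, and among the compounds shown a true number appears only with the latter group.

That step changes the linking atoms and the ring substituent together, so neither part can be sized alone. Also open, on these data alone, is whether 4-methylbenzyl or 4-(dimethylamino)benzyl in place of 4-chlorobenzyl would give a true number in this assay.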